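The source may hold more compounds than are shown below. What is called first, only, known or untested is meant among the compounds shown, and "the series" means these compounds.

Compound 3 `Oc1cnccc1CCCOc1cccnc1Oc1cccc(Br)c1` gives 50% in a functional assay on the whole organism for inhibition, with Mus musculus as the target, with stated times of 2 days and 30 min, at a dose of 10 mg/kg by the oral route; on this read-out higher numbers stand for more inhibition at the one dose given (going by the name of the read-out) and lower numbers for less inhibition. Compound 2 `Oc1cnccc1CCCOc1cccnc1Sc1cccc(Br)c1` gives 33%, and compound 1 `Brc1cccc(Cc2ncccc2OCCCc2ccncc2)c1` gives 43%; compound 3 lies beyond the scatter from compound 2 but within the scatter of compound 1. Compound 4 `Oc1cnccc1CCCOc1cccnc1Cc1cccc(Br)c1` is not yet measured. It differs from compound 3 by 3-bromobenzyl in place of 3-bromophenoxy on an aromatic carbon. Among the compounds with values here, the one measured step, a number 17 percentage points higher from compound 2 to compound 3 (beyond the scatter), concerns a different linking group and does not bear directly on this change. Compound 1 carries the same 3-bromobenzyl group, and its number sits within the scatter of compound 3. The step from compound 3 to compound 4 is therefore expected to be a number 5 percentage points lower from compound 3 to compound 4 (within the scatter), none beyond the scatter. Compound 4 is estimated at 45%, between 28% and 62%.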

Compound 4, a percentage reported as inhibition, in the whole organism at one dose (the size of the read-out at that dose, not a potency): 44%
Estimate against measurement, compound 4: 1 percentage points above; the measured number falls inside the stated range.
By their numbers in this assay, from the lowest: compounds 2, 1, 4 and 3 (each within the scatter of the next, the first and the last beyond it).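

In this assay 3-bromobenzyl, which carries no hydrogen-bond acceptor, stands in for 3-bromophenoxy next to the ring nitrogen with a number 6 percentage points lower from compound 3 to compound 4 (within the scatter). The same group set against (3-bromophenyl)sulfanyl gives a number 11 percentage points higher from compound 2 to compound 4 (beyond the scatter), so among these three groups only the sulfur-linked one falls apart from another beyond the scatter, and only from these two. With the 3-bromobenzyl group held fixed, hydroxy in place of hydrogen on an aromatic carbon gives a number 1 percentage points higher from compound 1 to compound 4 (within the scatter). Whether an amine link or a longer chain in this place would hold the number stays open, and no measurement shown gives a cause for these steps.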